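Replacing an Aminophenyl Ketone Arm with a Dichlorophenyl

The source may report more compounds than this note shows. Statements on the series, on what has been measured and on what is new or still open speak of the compounds shown alone.

Measured compounds:
compound 1, `COc1cc(-c2cc(/C=C/C(=O)c3ccc(N)cc3)[nH]n2)cc(OC)c1OC`, in a functional assay on SNB-19 cells (Homo sapiens) for cytotoxicity, read by sulforhodamine B assay, with a stated time of 48 h, tested at 0.01 uM; on this read-out lower numbers stand for a stronger effect and higher numbers for a weaker effect at the one concentration tested: 96%
compound 2, `COc1ccc(-c2cc(/C=C/C(=O)c3ccc(OC)c(OC)c3)[nH]n2)cc1`, in this assay: 96%

Compound 1 and compound 2 share the same core and differ in their aryl groups on either end, yet in this assay they sit level with each other at the digits shown, within the scatter. Both readings are high, so at this one concentration both compounds show only a weak effect on the cells.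

Compound 3, `COc1cc(-c2cc(/C=C/C(=O)c3ccc(Cl)c(Cl)c3)[nH]n2)cc(OC)c1OC`, is the next compound to be tested. Relative to compound 1 the change is 3,4-dichlorophenyl in place of 4-aminophenyl on a carbonyl carbon. Within the data shown here, no pair of measured compounds carries a step of this kind, so the size of the step is not known from the data. Given that compound 1 and compound 2 both read high in this assay, the step from compound 1 to compound 3 is expected to be a number 1 percentage points lower from compound 1 to compound 3 (within the scatter), that is, nothing beyond the scatter. For compound 3 the estimate in this assay is 95%, with a range from 85% to 104%.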

Compound 3, a percentage reported as activity, at one concentration (the size of the read-out at that concentration, not a potency): 100%
The estimate for compound 3 lay 5 percentage points below the measured number; measured number inside the range.
By their numbers in this assay, from the lowest: compounds 1, 2 and 3 (each within the scatter of the next).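

Among these compounds, the exchange of 4-aminophenyl for 3,4-dichlorophenyl on a carbonyl carbon is the first change at this position that can be read as a single step: in this assay it is a number 4 percentage points higher from compound 1 to compound 3 (within the scatter) and leaves the trimethoxyphenyl side of the molecule untouched. At the one concentration tested, this arm can therefore carry either group without the reading leaving the scatter, although readings this high leave little room to tell the two groups apart. No measurement shown gives a reason for this result.

As far as these compounds go, whether another group on the carbonyl carbon, such as a carboxylic acid or a morpholine, would bring the reading down remains open. So does whether compound 1 and compound 3 would still read alike at a higher concentration.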